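A few compounds are considered here, and "the series" means these few. Any claim that something is new, unique, unknown or untested is made for them only; others in the source may bear on it.

In a functional assay on SH-SY5Y cells (Homo sapiens) for cytotoxicity, read by MTT assay, with a stated time of 72 h (a higher number here means a weaker inhibitor, a lower number a stronger inhibitor), compound 3 (`CN1CCN(CCCCCn2c3c(c4ccccc42)C(=O)c2c[n+]([O-])c4ccccc4c2C3=O)CC1`) gives 830 nM and compound 2 (`CN1CCN(CCCCCCn2c3c(c4ccccc42)C(=O)c2c[n+]([O-])c4ccccc4c2C3=O)CC1`) gives 920 nM, the two lying within the scatter of each other, while compound 1 (`CCCCN1CCN(CCCCn2c3c(c4ccccc42)C(=O)c2c[n+]([O-])c4ccccc4c2C3=O)CC1`) gives 6100 nM. Compound 4 (`O=C1c2c[n+]([O-])c3ccccc3c2C(=O)c2c1c1ccccc1n2CCCN1CCC(O)CC1`) follows from compound 3 by 4-hydroxypiperidin-1-yl in place of 2-(4-methylpiperazin-1-yl)ethyl on a saturated chain carbon, three bonds along the chain from an aromatic nitrogen, with 4-hydroxypiperidin-1-yl in place of 2-(4-methylpiperazin-1-yl)ethyl on a saturated chain carbon, three bonds along the chain from an aromatic nitrogen. For the measured compounds named here, no measured step makes this exchange. The nearest guides are a 1.1-fold lower number from compound 2 to compound 3 (0.04 log units; within the scatter), within the scatter, and the modest 6.6-fold lower number from compound 1 to compound 2 (0.82 log units; beyond the scatter) and a 7.3-fold lower number from compound 1 to compound 3 (0.87 log units; beyond the scatter). A small move to a higher number is expected in this assay, probably within the scatter. The expected step is a 1.8-fold higher number from compound 3 to compound 4 (0.26 log units; within the scatter). For compound 4 the estimated value is 1500 nM, with an expected range of 450 nM to 6000 nM.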

Compound 4, half-maximal inhibitory concentration: 130 nM
Estimate against measurement, compound 4: 12-fold (1.06 log units) above; the measured number lies below the stated range.
By their numbers in this assay, from the lowest: compound 4; then compounds 3 and 2 (each within the scatter of the next); then compound 1.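

In this assay, the exchange for 3-(4-hydroxypiperidin-1-yl)propyl gives a 6.4-fold lower number from compound 3 to compound 4 (0.81 log units; beyond the scatter) and a 7.1-fold lower number from compound 2 to compound 4 (0.85 log units; beyond the scatter), so this change moves the number beyond the scatter, whereas the step between the two methylpiperazine compounds stayed within it. Against the butylpiperazine side chain, the exchange gives a 47-fold lower number from compound 1 to compound 4 (1.67 log units; beyond the scatter), a large step. Nothing available explains these steps.

Compound 4 differs from the others in both chain and terminal ring, so the two contributions remain unseparated. A plain piperidine or 4-methoxypiperidine on the propyl chain would test the hydroxyl.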